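The compounds below may be only part of what the source reports. "The series", "measured", "known", "first", "only" and "open" are said of these compounds alone.

Measured so far:
compound 1 `c1ccc(Sc2ccc(NC3=NCCN3)cc2)cc1` — 794 nM
compound 2 `FC(F)(F)c1ccc(Sc2ccc(NC3=NCCN3)cc2)cc1` — 50.1 nM

In an assay (Rattus norvegicus) for binding affinity to prostacyclin receptor (Homo sapiens), read by radioligand binding (a lower number here means a stronger inhibitor, a higher number a weaker inhibitor), compound 1 gives 794 nM, the highest of the two numbers; its nearest neighbour is compound 2, reached by a 16-fold lower number from compound 1 to compound 2 (1.20 log units; beyond the scatter). Compound 3 `CSc1ccc(NC2=NCCN2)cc1` is not yet measured. It differs from compound 1 by methyl in place of phenyl on a sulfur. For the measured compounds named here, no measured step covers this change directly. Going by the values given here, the one step that bears on it at all runs from compound 1 to compound 2, where a single trifluoromethyl placed on the phenyl moved the number by a 16-fold lower number from compound 1 to compound 2 (1.20 log units; beyond the scatter), so the part of the molecule that compound 3 loses is one where changes have shifted the result strongly. Among the compounds with values here, removing the whole phenyl and leaving only a methyl on the sulfur is therefore expected to move the number of compound 3 beyond the scatter, and more probably upward than downward, though no step shows which way. The expected step is a 3.8-fold higher number from compound 1 to compound 3 (0.58 log units; beyond the scatter). Compound 3 is estimated at 3000 nM in this assay, within a range from 700 nM to 15000 nM.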

Compound 3, inhibition constant: < 10000 nM
Compound 3: a limit, no number (the forecaster's own chance of this, stated with the estimate: 10%); the middle value does not contradict the limit.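

In this assay compound 3 gives < 10000 nM, which is a limit of the assay and not a number. No size can be read for the step between compound 1 and compound 3, whose result is only a limit: the limit of < 10000 nM in this assay, at which 1 of the 3 values shown sits.

The compounds shown leave open how far, and in which direction, methyl in place of phenyl on the sulfur moves the number.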